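Swapping the alkyne for a fluorophenyl at the acid side chain

The compounds below may be only part of what the source reports. "The series", "measured", "known", "first", "only" and "open" are said of these compounds alone.

In a functional assay on HEK293 cells for agonist activity at Free fatty acid receptor 1 (Homo sapiens), read by fluorescence and calcium flux, with a stated time of 10 min (a lower number here means that less compound is needed, a higher number that more compound is needed for the effect), compound 2 `CC#CC(CC(=O)O)c1ccc(OCC2COc3ccc(Cl)cc3O2)cc1` gives 100 nM, the lower of the two numbers recorded, while compound 1 `COCCOc1ccc2c(c1)OC(COc1ccc(CCC(=O)O)c(F)c1)CC2` gives 2370 nM, a difference well beyond the ordinary scatter of this assay. The two compounds differ in several places at once, so the data say only what their two values show and nothing about the weight of any single part.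

Compound 3 `O=C(O)CC(c1ccc(F)cc1)c1ccc(OCC2COc3ccc(Cl)cc3O2)cc1` has not yet been measured. It keeps the full framework of compound 2 and changes one thing: 4-fluorophenyl in place of prop-1-yn-1-yl on a saturated chain carbon bound to an aromatic carbon and a saturated chain carbon. Going by the values given here, no step between measured compounds isolates a change of this kind, so the expectation rests on the fact that the acid, its linking chain and the rest of the molecule remain those of compound 2, whose value of 100 nM is the natural anchor.

Compound 3 is expected to stay close to that anchor, with the step of a 2.5-fold higher number from compound 2 to compound 3 (0.40 log units; beyond the scatter) estimated to fall within or only slightly beyond the scatter. The estimate for compound 3 in this assay is 250 nM, with a range from 60 nM to 1000 nM.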

Compound 3, half-maximal effective concentration: 4310 nM
Compound 3: the middle estimate sits 17-fold (1.24 log units) below what was measured; measured number above the stated range.
By their numbers in this assay, from the lowest: compound 2; then compounds 1 and 3 (each within the scatter of the next).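

Going by these compounds alone, the step from prop-1-yn-1-yl to 4-fluorophenyl on this saturated chain carbon, a 43-fold higher number from compound 2 to compound 3 (1.63 log units; beyond the scatter), in this assay, gives the first reading of this position on its own, and it shows that the position is far from indifferent to the group it carries. Since the acid, its chain and the rest of the framework stay as in compound 2, this single replacement accounts for the whole step. The data offer no measurement that would explain it, and the swap changes several things at once, with 7 heavy atoms and an aromatic ring entering where 3 heavy atoms and a triple bond leave, so the two compounds cannot separate these features or assign a cause.

From the compounds shown here alone, whether a methyl, a cyclopropyl or a nitrile on this carbon would keep the number close to that of compound 2 remains open, as does whether an unsubstituted phenyl would behave like the 4-fluorophenyl of compound 3. Within the data shown here, it is also open whether a 4-fluorophenyl at this carbon would give a step of similar size on a different framework, since only one pair of compounds speaks to this change.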